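Phenyl in place of dimethoxyphenyl: what to expect for compound 4

A few compounds are considered here, and "the series" means these few. Any claim that something is new, unique, unknown or untested is made for them only; others in the source may bear on it.

Compound 1 `CCn1c(SCC(=O)Nc2ccc(C(C)=O)cc2)nnc1-c1ccc(OC)c(OC)c1` serves as the reference point of the series. In a functional assay on the whole organism (strain albino) for inhibition, with Rattus norvegicus as the target, read by paw edema, with stated times of 30 min and 3 h, at a dose of 0.28 mmol/kg by the oral route (a higher number here means more inhibition at the dose given (going by the name of the read-out), a lower number less inhibition), compound 1 gives 62%. Compound 2 `C=CCn1c(SCC(=O)Nc2ccc(C(C)=O)cc2)nnc1-c1ccc(OC)c(OC)c1` gives 58% and compound 3 `CCn1c(SCC(=O)Nc2ccc(C(C)=O)cc2)nnc1-c1cc(OC)c(OC)c(OC)c1` gives 54%; both steps from compound 1, a number 4 percentage points lower from compound 1 to compound 2 (within the scatter) and a number 8 percentage points lower from compound 1 to compound 3 (within the scatter), stay within the scatter, so the numbers shown do not set compound 1 apart from the other two. Compound 4 `CCn1c(SCC(=O)Nc2ccc(C(C)=O)cc2)nnc1-c1ccccc1` differs from compound 1 by phenyl in place of 3,4-dimethoxyphenyl on an aromatic carbon. Going by the values given here, only the step of a number 8 percentage points lower from compound 1 to compound 3 (within the scatter) concerns a methoxy on that ring, and it ran in the direction of adding one, with no effect beyond the scatter. The change to phenyl is therefore expected to give a number 5 percentage points lower from compound 1 to compound 4 (within the scatter), nothing beyond the scatter. Compound 4 is estimated at 57%, with a range from 44% to 70%.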

Compound 4, a percentage reported as inhibition, in the whole organism at one dose (the size of the read-out at that dose, not a potency): 56%
For compound 4 the middle estimate is 1 percentage points above the measured one; the measured number falls inside the stated range.
By their numbers in this assay, from the lowest: compounds 3, 4, 2 and 1 (each within the scatter of the next).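

Removing both methoxy groups at this position gives, in this assay, a number 6 percentage points lower from compound 1 to compound 4 (within the scatter). The earlier step only added a methoxy to the ring, whereas this one shows that the plain phenyl, on the ring carbon between two ring nitrogen atoms, stays within the scatter of the 3,4-dimethoxyphenyl at this dose. No measurement on hand accounts for the small difference. Open, on these data alone, is whether an amine or a carboxylic acid on this phenyl would move the number beyond the scatter. As far as these compounds go, a longer chain in place of the ethyl group also remains open.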